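Thiazol-2-yl in Place of Thiophen-2-yl: an Expected Step

The source may hold more compounds than are shown below. What is called first, only, known or untested is meant among the compounds shown, and "the series" means these compounds.

Three measured compounds share one core and differ only in the aromatic group attached to the amide-type nitrogen in a ring. In an assay on HEK293 cells for inhibition of P2X purinoceptor 7 (Homo sapiens), read by flow cytometry, with stated times of 15 min and 1 h (a lower number here means a stronger inhibitor, a higher number a weaker inhibitor), compound 1 `O=C(NCc1ccc(Cl)cc1Cl)[C@@H]1CCC(=O)N1c1cccs1` gives 229 nM; compound 2 `O=C(NCc1ccc(Cl)cc1Cl)[C@@H]1CCC(=O)N1c1ccco1` gives 244 nM, and compound 3 `O=C(NCc1ccc(Cl)cc1Cl)[C@@H]1CCC(=O)N1c1ccoc1` gives 200 nM. Compound 1 stands second highest of these three numbers, yet every gap is small: a 1.1-fold higher number from compound 1 to compound 2 (0.03 log units; within the scatter), a 1.1-fold lower number from compound 1 to compound 3 (0.06 log units; within the scatter) and a 1.2-fold lower number from compound 2 to compound 3 (0.09 log units; within the scatter). Compound 4 `O=C(NCc1ccc(Cl)cc1Cl)[C@@H]1CCC(=O)N1c1nccs1` is not yet measured; it carries 1,3-thiazol-2-yl in place of thiophen-2-yl on an amide-type nitrogen in a ring. Both earlier exchanges of one five-membered aromatic group for another, a 1.1-fold higher number from compound 1 to compound 2 (0.03 log units; within the scatter) and a 1.1-fold lower number from compound 1 to compound 3 (0.06 log units; within the scatter), stayed within the scatter, so no shift beyond the scatter is expected here either, giving an estimated 1.0-fold higher number from compound 1 to compound 4 (0.00 log units; within the scatter). Compound 4 is therefore estimated at 230 nM, with a range from 100 nM to 530 nM.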

Compound 4, half-maximal inhibitory concentration: 415 nM
Compound 4: middle estimate off by 1.8-fold (0.26 log units), on the low side, within the range that was stated.
By their numbers in this assay, from the lowest: compounds 3, 1, 2 and 4 (each within the scatter of the next, the first and the last beyond it).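

With 1,3-thiazol-2-yl, this position shows its first gap beyond the scatter in this assay (a 2.1-fold higher number from compound 3 to compound 4 (0.32 log units; beyond the scatter)), though a modest one. Within the data shown here, the steps to compound 4 from the other two compounds stay within the scatter (a 1.8-fold higher number from compound 1 to compound 4 (0.26 log units; within the scatter)) and (a 1.7-fold higher number from compound 2 to compound 4 (0.23 log units; within the scatter)), so only one pair of these aromatic groups can be told apart. No measurement shown explains that gap. Still open, from the compounds shown here alone, is how a six-membered aromatic group such as phenyl or pyridin-2-yl would behave on this nitrogen. The same question stands for a plain chain such as butyl.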